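Ethyl in Place of the Amide Hydrogen on Compound 2

This account rests on a few compounds, and the source may have more. Where it says the series, first, only, none or still open, it means among the compounds named here.

Compound 1 `CC1=C(C(=O)C2CC2)C(c2cccs2)NC(=O)N1`: 15%
Compound 2 `CCNC(=O)C1=C(C)NC(=O)NC1c1cccs1`: 4%

Compound 2 stands lowest of the two numbers in an assay on membranes from HeLa cells for displacement of a labelled ligand from adenosine receptor A3 (Homo sapiens), read by scintillation counting, with a stated time of 180 min, tested at 1 uM (a lower number here means less inhibition, a higher number more inhibition at the concentration tested (going by the name of the read-out)), and its nearest neighbour is compound 1, the two being separated by a number 11 percentage points lower from compound 1 to compound 2 (beyond the scatter), a modest step beyond the scatter. Compound 3 `CCN(CC)C(=O)C1=C(C)NC(=O)NC1c1cccs1` differs from compound 2 by ethyl in place of hydrogen on an amide-type nitrogen. For the measured compounds named here, no measured step concerns an ethyl group on the amide-type nitrogen; the single measured step, a number 11 percentage points lower from compound 1 to compound 2 (beyond the scatter), concerns a change on the carbonyl carbon. With nothing bearing directly on this change, compound 3 is expected to show a number 1 percentage points higher from compound 2 to compound 3 (within the scatter), a step within the scatter. Compound 3 is therefore estimated at 5%, between -10% and 20%.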

Compound 3, a percentage reported as inhibition, at one concentration (the size of the read-out at that concentration, not a potency): 31%
For compound 3 the middle estimate is 26 percentage points below the measured one; measured number above the stated range.
By their numbers in this assay, from the lowest: compound 2; then compound 1; then compound 3.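

In this assay, the amide-type nitrogen emerges as a place where the read-out responds: ethyl in place of hydrogen gives a number 27 percentage points higher from compound 2 to compound 3 (beyond the scatter) and turns ethylamino into diethylamino. The same carbonyl carbon therefore moves in opposite directions depending on the group replacing cyclopropyl, since diethylamino gives a number 16 percentage points higher from compound 1 to compound 3 (beyond the scatter) while ethylamino gave a number 11 percentage points lower from compound 1 to compound 2 (beyond the scatter) in the earlier step. Nothing available accounts for this reversal. From the compounds shown here alone, whether a longer chain such as propyl on this nitrogen, or a cyclic amine such as piperidine in place of diethylamino, would carry the number further remains open.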